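Three limits and one open piperazine

This account rests on a few compounds, and the source may have more. Where it says the series, first, only, none or still open, it means among the compounds named here.

In a functional assay on HCT-116 cells (Homo sapiens) for cytotoxicity, read by MTT assay, with a stated time of 72 h (on this read-out higher numbers stand for weaker inhibition and lower numbers for stronger inhibition), compound 1 `Nc1cccc(Nc2c(C(=O)NCc3ccc(F)cc3)nc(Br)c3cccnc23)c1` gives > 10000 nM as a limit. Compound 2 `CC(C)(C)OC(=O)N1CCN(c2c(C(=O)NCc3ccc(F)cc3)nc(Br)c3cccnc23)CC1` gives > 10000 nM as a limit too. Compound 3 `C[C@H](Nc1c(C(=O)NCc2ccc(F)cc2)nc(Br)c2cccnc12)c1ccccc1` stands at > 20000 nM and this is also only a limit, so no number places it. Compound 4 `O=C(NCc1ccc(F)cc1)c1nc(Br)c2cccnc2c1N1CCNCC1` follows from compound 3 by piperazin-1-yl in place of (1-phenylethyl)amino on an aromatic carbon para to a bromo group. Going by the values given here, the one measured step is a step that the two limits leave unreadable from compound 1 to compound 3 and it offers no size to carry over. With all three compounds at limits, only a modest gain at most is expected, and the estimated change is an at least 2.0-fold lower number from compound 3 to compound 4 (0.30 log units; that floor lies within the scatter) with little confidence. In this assay compound 4 is expected at 10000 nM with an estimated range from 3000 nM to 25000 nM as its span.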

Compound 4, half-maximal inhibitory concentration: > 10000 nM
Compound 4 ended at the assay's limit (the forecaster's own chance of this, stated with the estimate: 60%); the middle value lies on the limit itself.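

Compound 4 stands only at a limit, as do compound 1, compound 2 and compound 3, so none of its steps from those compounds can be read. The compounds shown leave open where any of them would actually fall in this assay.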